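Dropping the tert-butyl group: what to expect for compound 3

A few compounds are considered here, and "the series" means these few. Any claim that something is new, unique, unknown or untested is made for them only; others in the source may bear on it.

Compound 1 `O=C(COc1ccc(C(=O)/C=C/c2cccc(Cl)c2)cc1)N[C@H]1CCOC1=O` gives 20900 nM in a functional assay on MCF7 cells (Homo sapiens) for antiproliferative activity, read by MTT assay, with a stated time of 72 h; a higher number here means a weaker inhibitor, a lower number a stronger inhibitor. Compound 2 `CC(C)(C)c1ccc(/C=C/C(=O)c2ccc(OCC(=O)N[C@H]3CCOC3=O)cc2)cc1` gives 16400 nM in this assay.

Among the measured compounds shown here, compound 2 holds the lower of the two numbers, but its only neighbour, compound 1, sits at a 1.3-fold lower number from compound 1 to compound 2 (0.11 log units; within the scatter), so the two cannot be told apart. Compound 3 `O=C(COc1ccc(C(=O)/C=C/c2ccccc2)cc1)N[C@H]1CCOC1=O` differs from compound 2 by hydrogen in place of tert-butyl on an aromatic carbon. For the measured compounds named here, the one step that touches this same ring, a 1.3-fold lower number from compound 1 to compound 2 (0.11 log units; within the scatter), stayed within the scatter, which suggests that changing the group on that ring matters little. The expected change is therefore a 1.2-fold higher number from compound 2 to compound 3 (0.09 log units; within the scatter). Compound 3 is estimated at 20000 nM, within a range from 8000 nM to 50000 nM.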

Compound 3, half-maximal inhibitory concentration: > 64000 nM
Compound 3: a limit, no number; the forecaster's own chance of this, stated with the estimate: 10%; at least 3.2-fold (0.50 log units) between middle value and limit.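

Having some group on this ring turns out to matter, even though exchanging one group for another did not: in this assay, hydrogen in place of tert-butyl gives an at least 3.9-fold higher number from compound 2 to compound 3 (0.59 log units; beyond the scatter), and hydrogen in place of chloro gives an at least 3.0-fold higher number from compound 1 to compound 3 (0.48 log units; beyond the scatter). The plain phenyl ring of compound 3 thus stands apart from both substituted rings. Compound 3 has a limit, not a number: the limit of > 64000 nM in this assay, at which 1 of the 3 values shown sits.

As far as these compounds go, the real size of both steps therefore stays open. So does whether a smaller group on this ring, such as methyl or an amine, would bring the number back towards those of compound 1 and compound 2.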